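The source may hold more compounds than are shown below. What is called first, only, known or untested is meant among the compounds shown, and "the series" means these compounds.

Compound 1, whose structure is `Cc1cccc2c(NCc3ccco3)nc(NC(C)C)nc12`, and compound 2, whose structure is `Cc1ccc2nc(NC(C)C)nc(NCc3ccco3)c2c1`, are built from the same atoms joined differently; how the two cores differ is not broken down here. In a physicochemical assay for lipophilicity, at pH 3 (on this read-out lower numbers stand for lower lipophilicity and higher numbers for higher lipophilicity), compound 1 gives 1.57, and in this assay compound 2 gives 1.55, two numbers within the usual scatter of each other. Compound 3, whose structure is `COc1cccc2c(NCc3ccco3)nc(NC(C)C)nc12`, is derived from compound 1 by methoxy in place of methyl on an aromatic carbon; in this assay compound 3 gives 2.99, so the step is a number 1.42 log units higher from compound 1 to compound 3 (beyond the scatter). Compound 4, whose structure is `COc1ccc2nc(NC(C)C)nc(NCc3ccco3)c2c1`, is not yet measured in this assay; it is derived from compound 2 by methoxy in place of methyl on an aromatic carbon. This is the same kind of change as that from compound 1 to compound 3, though the place differs: in compound 3 the methoxy stands ortho to a fused ring and meta to a fused ring, in compound 4 meta to a fused ring and para to a fused ring. Among the compounds with values here, because the one measured step of this kind is a number 1.42 log units higher from compound 1 to compound 3 (beyond the scatter), a step of about a number 1.35 log units higher from compound 2 to compound 4 (beyond the scatter) is expected in this assay from compound 2 to compound 4. Compound 4 is therefore estimated at 2.9 in this assay, between 2.4 and 3.4.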

Compound 4, distribution coefficient: 2.95
For compound 4 the middle estimate is 0.05 log units below the measured one; low and high end bracket the measured number.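

In this assay, methoxy in place of methyl on an aromatic carbon gives a number 1.40 log units higher from compound 2 to compound 4 (beyond the scatter) and, on the other core, a number 1.42 log units higher from compound 1 to compound 3 (beyond the scatter). The change therefore carries from one core to the other in these two pairs, with both steps large and pointing the same way, although the methoxy stands at a different place on each core. This does not show that the step would hold on any further core or at any further place, and no evidence bears on what lies behind its size.

The compounds shown leave open whether a longer chain such as ethoxy would give a step of similar size on both cores, or whether an amine or a carboxylic acid at the same place would also travel from one core to the other. They also leave open whether the two steps would stay alike if the isopropylamino or furan-bearing parts of the molecule were changed.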